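Iodo in place of methyl in compound 2

A few compounds are considered here, and "the series" means these few. Any claim that something is new, unique, unknown or untested is made for them only; others in the source may bear on it.

Compound 1 `O=C1C=C(Nc2cccc(F)c2)C(=O)c2c1nc1n2[C@H]2OC[C@@H](O)[C@H]2OC1` gives 5500 nM in a functional assay on MCF7 cells (Homo sapiens) for inhibition, read by sulforhodamine B assay; on this read-out lower numbers stand for stronger inhibition and higher numbers for weaker inhibition
Compound 2 `Cc1ccc(NC2=CC(=O)c3nc4n(c3C2=O)[C@H]2OC[C@@H](O)[C@H]2OC4)cc1` gives 1660 nM in this assay

Among the compounds with values here, compound 2 holds the lower of the two numbers so far. Compound 3 `O=C1C=C(Nc2ccc(I)cc2)C(=O)c2c1nc1n2[C@H]2OC[C@@H](O)[C@H]2OC1` carries iodo in place of methyl on an aromatic carbon, para to a large group (iodo in place of methyl on an aromatic carbon). Within the data shown here, only one measured step bears on this: a 3.3-fold lower number from compound 1 to compound 2 (0.52 log units; beyond the scatter) is modest and also alters the phenyl group on the amine nitrogen, though it is not the same swap. The estimated step is a 1.2-fold higher number from compound 2 to compound 3 (0.08 log units; within the scatter) and so no shift beyond the scatter is expected in this assay for this change. For compound 3 the expected value is 2000 nM (700 nM to 5500 nM).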

Compound 3, half-maximal inhibitory concentration: 2230 nM
The estimate for compound 3 lay 1.1-fold (0.05 log units) below the measured number; the measured number falls inside the stated range.
By their numbers in this assay, from the lowest: compounds 2 and 3 (each within the scatter of the next); then compound 1.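

With a 1.3-fold higher number from compound 2 to compound 3 (0.13 log units; within the scatter) in this assay, iodo in place of methyl on this aromatic carbon, para to a large group, leaves the number within the scatter, so the two groups cannot be told apart here. Compound 3 also shows that the 4-methylphenyl group is not alone in giving a lower number than 3-fluorophenyl on the amine nitrogen, with a 2.5-fold lower number from compound 1 to compound 3 (0.39 log units; beyond the scatter) as the step. No evidence here speaks to the reason for either result. On these data alone, what an amine or a carboxylic acid would do at this same place stays open.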